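The source may hold more compounds than are shown below. What is called first, only, known or untested is meant among the compounds shown, and "the series" means these compounds.

Compound 1 `CN(Cc1ccc2nccn2c1)c1nnc(-c2ccc(-c3ccccc3)cc2)o1` gives 39.8 nM in an assay on isolated protein for inhibition of tyrosine-protein kinase Mer (Homo sapiens), read by LC-MS; on this read-out higher numbers stand for weaker inhibition and lower numbers for stronger inhibition.
Compound 2 `CN(Cc1ccc2nccn2c1)c1nnc(-c2ccc(-c3ccccc3F)cc2)o1` gives 15.9 nM in this assay.
Compound 3 `CN(Cc1ccc2nccn2c1)c1nnc(-c2ccc(-c3ccccc3C#N)cc2)o1` gives 25.1 nM in this assay.

Compound 3 stands second highest of the three numbers in this assay, and both of its neighbours lie within the scatter of it: the step of a 1.6-fold lower number from compound 1 to compound 3 (0.20 log units; within the scatter) is small, and the step of a 1.6-fold higher number from compound 2 to compound 3 (0.20 log units; within the scatter) is likewise small. Compound 4 `Cc1ccccc1-c1ccc(-c2nnc(N(C)Cc3ccc4nccn4c3)o2)cc1` differs from compound 3 by methyl in place of cyano on an aromatic carbon. Going by the values given here, the only steps that touch this position are a 2.5-fold lower number from compound 1 to compound 2 (0.40 log units; beyond the scatter), a modest gain, and a 1.6-fold lower number from compound 1 to compound 3 (0.20 log units; within the scatter) and a 1.6-fold higher number from compound 2 to compound 3 (0.20 log units; within the scatter), both within the scatter. Among the compounds with values here, no measured step covers a methyl at this carbon, so the size of the change is only loosely bounded. The three substituents tried so far all fall within a narrow band, and a methyl is expected to stay in it, so the step of a 1.0-fold lower number from compound 3 to compound 4 (0.00 log units; within the scatter) is estimated to lie within the scatter, with no clear direction. Compound 4 is therefore expected to give about 25 nM in this assay, with a range from 10 nM to 63 nM.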

Compound 4, half-maximal inhibitory concentration: 12.6 nM
Beside the measured number, compound 4's estimate is 2.0-fold (0.30 log units) above it; low and high end bracket the measured number.
By their numbers in this assay, from the lowest: compounds 4, 2, 3 and 1 (each within the scatter of the next, the first and the last beyond it).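

In this assay methyl joins fluoro as a replacement for hydrogen on this aromatic carbon, ortho to a large group, that moves the number beyond the scatter (a 3.2-fold lower number from compound 1 to compound 4 (0.50 log units; beyond the scatter)), whereas the cyano step from hydrogen stayed within it. Methyl cannot be separated from the other two substituents (a 2.0-fold lower number from compound 3 to compound 4 (0.30 log units; within the scatter); a 1.3-fold lower number from compound 2 to compound 4 (0.10 log units; within the scatter)), so the three cannot be ordered at this carbon. Methyl brings no hydrogen-bond acceptor where cyano has one, and the numbers show no loss from that exchange.

The compounds shown leave open whether a larger group at this carbon, such as methoxy, trifluoromethyl or an amine, would stay in the same band. Nothing available explains these numbers.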